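The source may report more compounds than this note shows. Statements on the series, on what has been measured and on what is new or still open speak of the compounds shown alone.

Measured compounds:
Compound 1 `COc1ccc(CCC2(C3CCCC3)CC(O)=C(Cc3nc4nc(C)cc(C)n4n3)C(=O)O2)cc1F` gives, in an ADME assay on Huh-7 cells (Homo sapiens) for cytotoxicity (a higher number here means that more compound is tolerated, a lower number that less compound is tolerated), a value of > 32000 nM, which is a limit of the assay.
Compound 2 `Cc1cc(C)n2nc(CC3=C(O)CC(CCc4ccc(S(C)(=O)=O)c(Cl)c4)(C4CCCC4)OC3=O)nc2n1` gives in this assay a value of > 32000 nM, also a limit of the assay.

Within the data shown here, compound 1 therefore stands at the limit of this assay, and the one further value shown is a limit as well; both sit at the limit of > 32000 nM in this assay, at which 2 of the 2 values shown sit. Among the measured compounds shown here, the single measured step, a step that the two limits leave unreadable from compound 1 to compound 2, is thus not readable in size or direction.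

Compound 3 `Cc1cc(C)n2nc(CC3=C(O)CC(CCc4ccc(C(C)(C)NS(C)(=O)=O)c(F)c4)(C4CCCC4)OC3=O)nc2n1` differs from compound 1 by 1-(methanesulfonamido)-1-methylethyl in place of methoxy on an aromatic carbon. For the measured compounds named here, no measured step resembles this change, and the only step available gives no readable size. No step beyond the scatter can be expected in either direction, and compound 3 is expected to remain at the limit, an estimated step of a number no higher from compound 1 to compound 3 (the limit leaves the size open).

Compound 3 is estimated at 32000 nM, within a range of 10000 nM to 100000 nM.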

Compound 3, half-maximal cytotoxic concentration: > 32000 nM
Compound 3: a limit, no number; the forecaster's own chance of this, stated with the estimate: 85%; the middle value lies on the limit itself.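

Among these compounds, compound 3 gives > 32000 nM in this assay, which is a limit of the assay, so no step from compound 1 or compound 2 to compound 3 can be read. All three values rest on one limit: the limit of > 32000 nM in this assay, at which 3 of the 3 values shown sit.

What the compounds shown leave open is how much compound each tolerates in this assay, and whether the changes among them alter it at all.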